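The source may report more compounds than this note shows. Statements on the series, on what has been measured and on what is new or still open speak of the compounds shown alone.

In a functional assay on ACHN cells (Homo sapiens) for inhibition, read by sulforhodamine B assay, with a stated time of 48 h, tested at 10 uM (on this read-out lower numbers stand for less inhibition and higher numbers for more inhibition at the one concentration tested (going by the name of the read-out)), compound 3 `c1ccc2c(-c3cn4ccnc4c(-c4ccc5ncn(C6CCCCC6)c5c4)n3)cccc2c1` gives 6.49%, the lowest of the three numbers seen so far. Compound 1 `Brc1cn2ccnc2c(-c2ccc3ncn(C4CCCCC4)c3c2)n1` gives 11.5%, which lies within the scatter of compound 3, while compound 2 `c1ccc(-c2cn3ccnc3c(-c3ccc4ncn(C5CCCCC5)c4c3)n2)cc1` gives 35.9%, beyond it. Compound 4 `c1cn2cc(-c3ccsc3)nc(-c3ccc4ncn(C5CCCCC5)c4c3)c2n1` differs from compound 3 by thiophen-3-yl in place of naphthalen-1-yl on an aromatic carbon. Among the compounds with values here, two measured steps bear on this change: a number 24.4 percentage points higher from compound 1 to compound 2 (beyond the scatter) and a number 29.4 percentage points lower from compound 2 to compound 3 (beyond the scatter), both modest and beyond the scatter, and in both the number is higher with phenyl than with bromo or with naphthalen-1-yl. Thiophen-3-yl, one five-membered aromatic ring, stands nearer to phenyl than to the two fused six-membered rings of naphthalen-1-yl, so a modest rise is expected, a number 18.5 percentage points higher from compound 3 to compound 4 (beyond the scatter). Compound 4 is therefore estimated at 25%, with a range from 8% to 45%.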

Compound 4, a percentage reported as inhibition, at one concentration (the size of the read-out at that concentration, not a potency): 5.76%
Compound 4: the middle estimate sits 19.2 percentage points above what was measured; the whole stated range lies above it.
By their numbers in this assay, from the lowest: compounds 4, 3 and 1 (each within the scatter of the next); then compound 2.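

At this place, next to the ring nitrogen, thiophen-3-yl does not keep the number that phenyl gives in this assay (a number 30.1 percentage points lower from compound 2 to compound 4 (beyond the scatter)), and it cannot be told apart from naphthalen-1-yl (a number 0.7 percentage points lower from compound 3 to compound 4 (within the scatter)) or bromo (a number 5.7 percentage points lower from compound 1 to compound 4 (within the scatter)). Among the four groups shown, phenyl alone stands apart, so a single aromatic ring at this place is not enough for the higher number. Nothing measured here explains why phenyl differs from thiophen-3-yl. Going by these compounds, whether an amine or a carboxylic acid on the phenyl would keep, raise or lose that number remains open.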